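This account rests on a few compounds, and the source may have more. Where it says the series, first, only, none or still open, it means among the compounds named here.

In a functional assay on EC9706 cells (Homo sapiens) for antiproliferative activity, read by MTT assay, with a stated time of 48 h (a higher number here means a weaker inhibitor, a lower number a stronger inhibitor), compound 3 (`CCCCCCCCCCCCn1cc(COC[C@@H]2OC[C@H](N)[C@H]2O)nn1`) gives 93800 nM as the higher of the two actual numbers in the series, with compound 2 (`CCCCCCCCCCn1cc(COC[C@@H]2OC[C@H](N)[C@H]2O)nn1`) nearest on the lower side at 43100 nM in the same read-out. Compound 1 (`CCCCCCCn1cc(COC[C@@H]2OC[C@H](N)[C@H]2O)nn1`) gives > 128000 nM as a limit of the assay and not a number.

The change leading to compound 4 (`CCCCCCCCCCCCCCn1cc(COC[C@@H]2OC[C@H](N)[C@H]2O)nn1`) is ethyl in place of hydrogen on a saturated chain carbon, ten or more bonds along the chain from an aromatic nitrogen and nothing else. The same change has one measured precedent, a 2.2-fold higher number from compound 2 to compound 3 (0.34 log units; beyond the scatter) and this modest step is the closest guide. The shorter-chain steps, an at least 2.9-fold lower number from compound 1 to compound 2 (0.47 log units; beyond the scatter) and an at least 1.3-fold lower number from compound 1 to compound 3 (0.13 log units; that floor lies within the scatter) start from a limit and bear on the direction less directly. Compound 1 and compound 3 both go against any steady gain with chain length.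

A further rise in the number is expected in this assay and readings near the limit of > 128000 nM in this assay, at which 1 of the 3 values shown sits, may come back only as a limit. The estimated step is a 1.4-fold higher number from compound 3 to compound 4 (0.14 log units; within the scatter) and so smaller than the measured one. For compound 4 the estimate is 130000 nM with an expected range from 50000 nM to 300000 nM in this assay.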

Compound 4, half-maximal inhibitory concentration: 6680 nM
Compound 4: middle estimate off by 19-fold (1.29 log units), on the high side; measured number outside the range, below it.
By their numbers in this assay, from the lowest: compound 4; then compound 2; then compound 3. At a limit, above all of these: compound 1.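

In this assay, the same ethyl in place of hydrogen on a saturated chain carbon now lowers the number (a 14-fold lower number from compound 3 to compound 4 (1.15 log units; beyond the scatter)), whereas its one earlier occurrence raised it, so this change has no single direction at this position. The lowest number in the series sits with compound 4 (a 6.5-fold lower number from compound 2 to compound 4 (0.81 log units; beyond the scatter)), but the trend with chain length is not steady, and compound 3 goes against any continuous fall. The step from the shortest chain (an at least 19-fold lower number from compound 1 to compound 4 (1.28 log units; beyond the scatter)) is only a floor, as it starts from a limit of the assay and not a number: the limit of > 128000 nM in this assay, at which 1 of the 4 values shown sits.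

Going by these compounds, whether the number keeps falling with a longer chain remains open. So does the effect of a chain carrying an amine or a carboxylic acid.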